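This account rests on a few compounds, and the source may have more. Where it says the series, first, only, none or still open, it means among the compounds named here.

Compound 3 has the structure `Fc1ccccc1NC(=S)N/N=C/c1ccc2ccccc2n1`. In a functional assay on SGC-7901 cells (Homo sapiens) for antiproliferative activity, read by sulforhodamine B assay, with a stated time of 72 h (on this read-out higher numbers stand for weaker inhibition and lower numbers for stronger inhibition), compound 3 gives > 100000 nM, which is a limit of the assay and not a number. Two related compounds were measured in the same way. Compound 1, with structure `COc1ccccc1NC(=S)N/N=C/c1ccc2ccccc2n1`, gives in this assay > 100000 nM, again a limit. Compound 2, with structure `COc1ccc(C)cc1NC(=S)N/N=C/c1ccc2ccccc2n1`, gives in this assay only the limit > 100000 nM. What is known of the three is thus the limit of > 100000 nM in this assay, at which 3 of the 3 values shown sit, alone; the step that the two limits leave unreadable from compound 1 to compound 2 and the step that the two limits leave unreadable from compound 1 to compound 3 cannot be sized from such values. Compound 4, with structure `Cc1cccc(NC(=S)N/N=C/c2ccc3ccccc3n2)c1`, differs from compound 3 by 3-methylphenyl in place of 2-fluorophenyl on an amide-type nitrogen. Among the compounds with values here, none of the measured steps touches this exchange, and the two steps that are known give no readable size in any case. The step that the limit leaves unreadable from compound 3 to compound 4 is therefore expected to be no change beyond the scatter, with the outcome most likely another limit. The estimate for compound 4 in this assay is 150000 nM, with a range from 50000 nM to 500000 nM, and it is expected that the assay will more often report a limit than a number for compound 4.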

Compound 4, half-maximal inhibitory concentration: > 100000 nM
Compound 4: only a limit was reported; the forecaster's own chance of this, stated with the estimate: 80%; the middle value does not contradict the limit.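

In this assay compound 4 gives > 100000 nM, a limit and not a number, so none of the steps from compound 1, compound 2 or compound 3 to compound 4 can be read. The compounds shown leave open whether any exchange of the group on the amide-type nitrogen changes activity at all, for all of them rest at one limit: the limit of > 100000 nM in this assay, at which 4 of the 4 values shown sit.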